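A Pyridinylmethyl Swap on a Scaffold Without Measurable Agonism

This account rests on a few compounds, and the source may have more. Where it says the series, first, only, none or still open, it means among the compounds named here.

Compound 1 `CC1(C)CCC(NCc2ccc(CN(C[C@H]3Cc4ccccc4CN3)[C@H]3CCCc4cccnc43)cc2)CC1` bears a 4,4-dimethylcyclohexyl group on an amine nitrogen. In a functional assay on cells for agonist activity at C-X-C chemokine receptor type 4 (Homo sapiens), read by fluorescence and calcium flux, with a stated time of 90 s (on this read-out higher numbers stand for an effect only at larger amounts of compound and lower numbers for an effect already at smaller amounts), compound 1 gives only a limit of the assay, > 30000 nM. Compound 2 `c1ccc(CNCc2ccc(CN(C[C@H]3Cc4ccccc4CN3)[C@H]3CCCc4cccnc43)cc2)nc1` differs from compound 1 by (pyridin-2-yl)methyl in place of 4,4-dimethylcyclohexyl on an amine nitrogen. In this assay compound 2 also gives only a limit, > 30000 nM. The step between them, a step that the two limits leave unreadable from compound 1 to compound 2, cannot be sized because the limit of > 30000 nM in this assay, at which 3 of the 3 values shown sit, covers both ends of it.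

Compound 3 `CC1(C)CCC(NC/C=C/CN(C[C@H]2Cc3ccccc3CN2)[C@H]2CCCc3cccnc32)CC1` has a different core; how it differs from the core of compound 1 is not broken down here. In this assay compound 3 likewise gives only a limit, > 30000 nM.

Compound 4 `C(=C/CN(C[C@H]1Cc2ccccc2CN1)[C@H]1CCCc2cccnc21)\CNCc1ccccn1` has not yet been measured. It differs from compound 3 by (pyridin-2-yl)methyl in place of 4,4-dimethylcyclohexyl on an amine nitrogen, the same change as that from compound 1 to compound 2, made at the same place. Among the compounds shown the change occurs twice in all.

The expected step is a step that the limit leaves unreadable from compound 3 to compound 4, and this expectation rests on compound 1 and compound 2 both sitting at the limit of > 30000 nM in this assay, at which 3 of the 3 values shown sit, with no readable movement between them. For compound 4 the estimated value in this assay is 50000 nM, expected to lie between 10000 nM and 300000 nM, and most likely the assay will again report only a limit rather than a number.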

Compound 4, half-maximal effective concentration in the C-X-C chemokine receptor type 4 assay: > 30000 nM
Compound 4 ended at the assay's limit; the forecaster's own chance of this, stated with the estimate: 85%; the middle value is on the limit's open side.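

In the C-X-C chemokine receptor type 4 assay compound 3 gives only a limit of the assay, > 30000 nM. In the C-X-C chemokine receptor type 4 assay compound 4 also gives only a limit of the assay, > 30000 nM. No step can be read from compound 3 to compound 4 in the C-X-C chemokine receptor type 4 assay, because both compounds end at a limit of the assay rather than at a number: the limit of > 30000 nM in the C-X-C chemokine receptor type 4 assay, at which 4 of the 4 values shown sit.

The compounds shown leave open what size of effect, if any, (pyridin-2-yl)methyl in place of 4,4-dimethylcyclohexyl on an amine nitrogen has in the C-X-C chemokine receptor type 4 assay, where none of them gives a number.

In a physicochemical assay for permeability, using PAMPA, with a stated time of 4 h, at pH 7.4, tested at 100 uM (a higher number here means that the compound crosses the layer faster, a lower number that the compound crosses the layer more slowly), compound 3 is reported as "not determined" (no result reported). In the physicochemical assay compound 4 gives 50 nm/s. No comparison between the two compounds can be made in this measurement.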